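Removing One Hydroxy Group: Cytotoxicity in Skin Cells

The compounds below may be only part of what the source reports. "The series", "measured", "known", "first", "only" and "open" are said of these compounds alone.

Of the compounds shown here, three have so far been tested in an ADME assay on BJ cells (Homo sapiens) for cytotoxicity, read by fluorescence, with a stated time of 24 h; on this read-out higher numbers stand for weaker inhibition and lower numbers for stronger inhibition. Among the compounds with values here, compound 1 `O=C1N/C(=N/N=C/c2c(-c3ccc(Br)cc3)[nH]c3ccccc23)SC1CCO` is the only one that returns a number: in this assay compound 1 gives 29200 nM. Compound 2 `CCOC(=O)c1sc(N/N=C/c2c(-c3ccc(Cl)cc3)[nH]c3ccccc23)nc1C` returns only a limit of the assay, > 50000 nM. Compound 3 `C=CCN1C(=O)C(CC(=O)c2ccc(F)cc2)S/C1=N\N=C1\CC2CCC1(C)C2(C)C` likewise returns only a limit of the assay, > 50000 nM. Within the data shown here, compound 1 therefore stands as the single measured value, while the other two sit at the limit of > 50000 nM in this assay, at which 2 of the 3 values shown sit, where no comparison of size is possible. No pair among these three differs in only one place, so no single step between measured compounds can be read off.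

Compound 4 `CCC1S/C(=N\N=C\c2c(-c3ccc(Br)cc3)[nH]c3ccccc23)NC1=O` has not yet been measured. It differs from compound 1 in one place: hydrogen in place of hydroxy on a saturated chain carbon, two bonds along the chain from a saturated ring carbon. Hydroxy leaves and hydrogen enters, so that the 2-hydroxyethyl becomes ethyl.

Among the measured compounds shown here, no measured step shows what this change does in these cells, so the expectation rests on how small the change is, a single heavy atom on a chain. The step of a 1.2-fold lower number from compound 1 to compound 4 (0.07 log units; within the scatter) is expected to stay within the usual scatter, with no clear direction. The estimate for compound 4 is 25000 nM, within a range from 10000 nM to 50000 nM.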

Compound 4, half-maximal inhibitory concentration: 7450 nM
Estimate against measurement, compound 4: 3.4-fold (0.53 log units) above; measured number outside the range, below it.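

Within the data shown here, this is the first single change that can be read in this assay: hydrogen in place of hydroxy, which turns the 2-hydroxyethyl into ethyl, gives a 3.9-fold lower number from compound 1 to compound 4 (0.59 log units; beyond the scatter). On this read-out a lower number stands for stronger inhibition, so this chain is not a silent place on the molecule: one oxygen atom on it is enough to shift the effect on these skin cells, modestly but beyond the usual scatter. Among these compounds, nothing measured so far gives a reason for the shift.

The compounds shown leave open how other groups at this place on the chain would behave, such as a methoxy, an amine or a carboxylic acid at the chain end, or a longer chain such as propyl, any of which could show whether the number keeps falling or turns back. They also leave open whether the same swap of hydroxy for hydrogen would move the number the same way on a different core, as the change can so far be read in this one pair alone.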